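The source may report more compounds than this note shows. Statements on the series, on what has been measured and on what is new or still open speak of the compounds shown alone.

Working notes on the series. In a functional assay on HCT-15 cells (Homo sapiens) for cytotoxicity, read by colorimetric assay and MTT assay (on this read-out lower numbers stand for stronger inhibition and higher numbers for weaker inhibition), compound 1 `CCN(CC)C(=O)Cn1c(=O)c(-c2ccc(OC)cc2)cc2c(OC)cc(OC)cc21` gives 10000 nM, compound 2 `COc1ccc(-c2cc3c(OC)cc(OC)cc3n(CC#N)c2=O)cc1` gives 10000 nM and compound 3 `COc1ccc(-c2cc3c(OC)cc(OC)cc3n(CCC#N)c2=O)cc1` gives 10000 nM. Compound 3 therefore stands level with the other two at the digits available. The next entry is compound 4 `COc1ccc(-c2cc3c(OC)cc(OC)cc3n(CCC(=O)OCc3ccccc3)c2=O)cc1`, reached by benzyloxycarbonyl in place of cyano on a saturated chain carbon, two bonds along the chain from an aromatic nitrogen. For the measured compounds named here, three measured steps bear on this chain: no change at the digits printed from compound 1 to compound 2 (within the scatter), no change at the digits printed from compound 1 to compound 3 (within the scatter) and no change at the digits printed from compound 2 to compound 3 (within the scatter). None of them moves the read-out. None of them brings in a six-membered aromatic ring either, and the data do not cover that part of the change. The expectation in this assay is no step beyond the scatter, with the open side towards stronger inhibition. The expected size of the step is a 1.3-fold lower number from compound 3 to compound 4 (0.10 log units; within the scatter). For compound 4 the estimated value is 8000 nM, with an expected range of 2500 nM to 12000 nM.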

Compound 4, half-maximal inhibitory concentration: 10000 nM
Beside the measured number, compound 4's estimate is 1.3-fold (0.10 log units) below it, and the stated range covers the measured number.
By their numbers in this assay, from the lowest: compounds 1, 2, 3 and 4 (each within the scatter of the next).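

In this assay, for the compounds shown here, the benzyloxycarbonyl group brings in a six-membered aromatic ring of carbon only, the part of the change the earlier compounds did not cover, and the read-out shows no change at the digits printed from compound 3 to compound 4 (within the scatter) even so. The same holds when the change is read from the other two compounds, with no change at the digits printed from compound 2 to compound 4 (within the scatter) and no change at the digits printed from compound 1 to compound 4 (within the scatter) as well, so the four chains on the aromatic nitrogen are not told apart by this read-out. Nothing at hand gives a reason for this flat result.

Still open, on these data alone, is whether a primary amine or a free carboxylic acid at the end of this chain, in place of the benzyl ester, would leave the level of these four compounds. Also open, as far as these compounds go, is whether a longer chain carrying the same benzyloxycarbonyl group would read any differently.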